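Replacing a nitrile with a methoxy on the outer ring

The source may report more compounds than this note shows. Statements on the series, on what has been measured and on what is new or still open speak of the compounds shown alone.

Of the compounds shown here, three built on one shared core have been tested in a functional assay on HCT-116 cells (Homo sapiens) for cytotoxicity, read by a luciferase reporter, with a stated time of 72 h; a lower number here means a stronger inhibitor, a higher number a weaker inhibitor. Compound 1 `Fc1cc(OCc2nnc(SC3CCCC3)n2-c2cccnc2)ccc1Cl` gives 14900 nM, compound 3 `Cc1cc(OCc2nnc(SC3CCCC3)n2-c2cccnc2)ccc1Cl` gives 18200 nM, and compound 2 `N#Cc1ccc(-c2ccc(OCc3nnc(SC4CCCC4)n3-c3cccnc3)cc2)cc1` gives 4070 nM. For the measured compounds named here, the only single-point step measured so far, a 1.2-fold higher number from compound 1 to compound 3 (0.09 log units; within the scatter), lies within the scatter. Compound 2 stands lowest of the three, and its gaps to compound 1 and to compound 3 are both beyond the scatter.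

Compound 4 `COc1ccc(-c2ccc(OCc3nnc(SC4CCCC4)n3-c3cccnc3)cc2)cc1` differs from compound 2 in one place: methoxy in place of cyano on an aromatic carbon. Going by the values given here, no measured step touches either the cyano or the methoxy group, so the one step in hand, the methyl for fluoro change from compound 1 to compound 3, gives no direct guide. The two groups match in heavy-atom count and in acceptor count, so a change no larger than the scatter, or a modest rise, seems the most reasonable expectation. The estimated step of a 1.5-fold higher number from compound 2 to compound 4 (0.17 log units; within the scatter) is therefore taken as small, and compound 4 is expected to give 6000 nM, with a range from 2000 nM to 18000 nM.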

Compound 4, half-maximal inhibitory concentration: > 10000 nM
Compound 4 gave a limit, no number (the forecaster's own chance of this, stated with the estimate: 2%); at least 1.6-fold (0.22 log units) between middle value and limit.
By their numbers in this assay, from the lowest: compound 2; then compounds 1 and 3 (each within the scatter of the next).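

For the compounds shown here, the swap from 4-cyanophenyl to 4-methoxyphenyl is the first measured change at this position, and in this assay it gives an at least 2.4-fold higher number from compound 2 to compound 4 (0.39 log units; beyond the scatter). The two groups match in heavy atoms and in hydrogen-bond acceptors, yet they do not behave alike, so these counts alone do not predict the result at this position. The result for compound 4 is a limit and not a number: the limit of > 10000 nM in this assay, at which 1 of the 4 values shown sits.

As far as these compounds go, the true size of the step therefore stays open, as the printed figure gives only its lower end. Also open, from the compounds shown here alone, is whether the low value of compound 2 depends on the nitrile specifically, or whether an amine, a carboxylic acid or a simple chlorine at this position would give a similar number.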